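Cyclopropyl in Place of Fluorophenyl at the Imidazole Side Chain

A few compounds are considered here, and "the series" means these few. Any claim that something is new, unique, unknown or untested is made for them only; others in the source may bear on it.

In an in vitro functional assay on cells for agonist activity at Bombesin receptor subtype-3 (Mus musculus), read by luminescence and calcium flux (a lower number here means that less compound is needed, a higher number that more compound is needed for the effect), compound 3 `O=C(O)c1ccccc1-c1ccc(CCc2ncc(Cc3ccc(F)cc3)[nH]2)cc1` gives 50 nM, the lowest of the three numbers. Its nearest neighbour is compound 1 `CCCCc1cnc(CCc2ccc(-c3ccccc3C(=O)O)cc2)[nH]1`, which gives 93 nM; the step is a 1.9-fold lower number from compound 1 to compound 3 (0.27 log units; within the scatter). The furthest is compound 2 `Cc1ccc(Cc2cnc(CCc3ccc(-c4ccccc4C(=O)O)cc3)[nH]2)cc1`, which gives 162 nM; the step is a 3.2-fold lower number from compound 2 to compound 3 (0.51 log units; beyond the scatter). Compound 4 `O=C(O)c1ccccc1-c1ccc(CCc2ncc(CC3CC3)[nH]2)cc1` differs from compound 3 by cyclopropyl in place of 4-fluorophenyl on a saturated chain carbon bound to an aromatic carbon. Among the compounds with values here, no measured step exchanges an aromatic ring for a non-aromatic one, but compound 1, carrying propyl at the same place, shows that a small saturated group there leaves the number close, as a 1.9-fold lower number from compound 1 to compound 3 (0.27 log units; within the scatter) lies within the scatter. The step of a 1.8-fold higher number from compound 3 to compound 4 (0.26 log units; within the scatter) is therefore expected to be small. Compound 4 is estimated at 90 nM, within a range of 35 nM to 250 nM.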

Compound 4, half-maximal effective concentration: 72 nM
Compound 4: the middle estimate sits 1.3-fold (0.10 log units) above what was measured; measured number inside the range.
By their numbers in this assay, from the lowest: compounds 3, 4, 1 and 2 (each within the scatter of the next, the first and the last beyond it).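

In this assay the saturated chain carbon bound to an aromatic carbon tolerates a non-aromatic three-membered ring in place of an aromatic ring: cyclopropyl for 4-fluorophenyl gives a 1.4-fold higher number from compound 3 to compound 4 (0.16 log units; within the scatter) and cyclopropyl for propyl gives a 1.3-fold lower number from compound 1 to compound 4 (0.11 log units; within the scatter). Only the exchange of 4-methylphenyl for cyclopropyl goes beyond the scatter, with a 2.3-fold lower number from compound 2 to compound 4 (0.35 log units; beyond the scatter). No evidence is available that accounts for these numbers. As far as these compounds go, whether an amine or a longer chain at this place would keep the number stays open.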